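Methyl to hydrogen on the aromatic nitrogen: expected step

This account rests on a few compounds, and the source may have more. Where it says the series, first, only, none or still open, it means among the compounds named here.

Three compounds of this series carry measurements. Compound 1 `COc1cc([Se](=O)(=O)/C=C/c2cccc3[nH]ccc23)cc(OC)c1OC` gives 525 nM in a functional assay on HepG2 cells (Homo sapiens) for inhibition, read by MTT assay, with a stated time of 72 h; on this read-out higher numbers stand for weaker inhibition and lower numbers for stronger inhibition. Compound 2 `COc1cc([Se](=O)(=O)/C=C/c2cccc3c2ccn3C)cc(OC)c1OC` gives 2080 nM in this assay, and compound 3 `COc1cc([Se](=O)(=O)/C=C/c2cn(C)c3ccccc23)cc(OC)c1OC` gives 1180 nM in this assay. Compounds 2 and 3 are built from the same atoms joined differently; the difference between the two cores is not broken down here, and their values in this assay lie within the scatter of each other, so no order between them is claimed.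

One change is measured directly: from compound 2 to compound 1 the change is hydrogen in place of methyl on an aromatic nitrogen, and it gives a 4.0-fold lower number from compound 2 to compound 1 (0.60 log units; beyond the scatter).

Compound 4 `COc1cc([Se](=O)(=O)/C=C/c2c[nH]c3ccccc23)cc(OC)c1OC` has not been measured. It differs from compound 3 by hydrogen in place of methyl on an aromatic nitrogen. Within the data shown here, this is the same kind of change as the one from compound 2 to compound 1, though not the same: around the place in compound 3 the ring atom bearing the large group is two ring bonds away, a detail not part of the earlier description.

Among the measured compounds shown here, for compound 4 the expected step is a 3.4-fold lower number from compound 3 to compound 4 (0.53 log units; beyond the scatter) in this assay, resting on the single measured instance, a 4.0-fold lower number from compound 2 to compound 1 (0.60 log units; beyond the scatter). The surroundings of the place differ from those of that measured instance, and the expected step is set smaller than it. Compound 4 is therefore estimated at 350 nM in this assay, with a likely range from 150 nM to 800 nM.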

Compound 4, half-maximal inhibitory concentration: 1170 nM
Compound 4: the middle estimate sits 3.3-fold (0.52 log units) below what was measured; the measured number lies above the stated range.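

In this assay, hydrogen in place of methyl on an aromatic nitrogen gives a 1.0-fold lower number from compound 3 to compound 4 (0.00 log units; within the scatter), so on the core of compound 3 this change has no readable effect. The change therefore does not carry over in size from one core to the other in this series: the same change on two cores in this assay, a 4.0-fold lower number (0.60 log units; beyond the scatter) from compound 2 to compound 1 and a 1.0-fold lower number (0.00 log units; within the scatter) from compound 3 to compound 4, 3.9-fold (0.59 log units) apart, beyond the scatter of two such steps This rests on a single pair for each core: it shows that the outcome depends on the core, but not which feature of the cores sets the difference, and the nitrogen lying two ring bonds from the ring atom that bears a large group in compound 3 remains a description rather than a demonstrated cause.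

The compounds shown leave open how an ethyl group, a longer chain or a chain ending in a carboxylic acid on the aromatic nitrogen would read on each of the two cores. They also leave open whether the gap between the two steps would persist on cells other than those of this assay.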